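Compound 4: from 4-bromophenyl to phenyl

A few compounds are considered here, and "the series" means these few. Any claim that something is new, unique, unknown or untested is made for them only; others in the source may bear on it.

Compound 1 `COc1cccc(C(=O)Nc2nnc(/C=C/c3cc(OC)c(OC)c(OC)c3Br)s2)c1`: 60 nM
Compound 2 `COc1cc(/C=C/c2nnc(NC(=O)c3ccc(Br)cc3)s2)c(Br)c(OC)c1OC`: 160 nM
Compound 3 `COc1cc(/C=C/c2nnc(NC(=O)c3cccc(O)c3)s2)cc(OC)c1OC`: 190 nM

In a functional assay on A549 cells (Homo sapiens) for antiproliferative activity, read by MTT assay, with a stated time of 48 h (a lower number here means a stronger inhibitor, a higher number a weaker inhibitor), compound 2 gives 160 nM. That value lies within the scatter of compound 3, while compound 1 shows a lower number, beyond the scatter. Compound 4 `COc1cc(/C=C/c2nnc(NC(=O)c3ccccc3)s2)c(Br)c(OC)c1OC` carries hydrogen in place of bromo on an aromatic carbon, para to a large group: hydrogen in place of bromo on an aromatic carbon. Going by the values given here, the one measured step touching this group is a 2.7-fold higher number from compound 1 to compound 2 (0.43 log units; beyond the scatter), and it is modest. Among the compounds with values here, it swaps 3-methoxyphenyl for 4-bromophenyl, so no measured pair shows the bromo removed alone. A step no larger than that one is therefore expected, in neither direction beyond the scatter. The expected change is a 1.1-fold lower number from compound 2 to compound 4 (0.06 log units; within the scatter). Compound 4 is estimated at 140 nM, with an expected range of 50 nM to 400 nM.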

Compound 4, half-maximal inhibitory concentration: 110 nM
Compound 4: the middle estimate sits 1.3-fold (0.10 log units) above what was measured; measured number inside the range.
By their numbers in this assay, from the lowest: compounds 1, 4, 2 and 3 (each within the scatter of the next, the first and the last beyond it).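

In this assay, going by these compounds alone, taking off the bromo alone gives a 1.5-fold lower number from compound 2 to compound 4 (0.16 log units; within the scatter), so this pair isolates the position for the first time and the change stays within the scatter. Hydrogen in place of methoxy gives a 1.8-fold higher number from compound 1 to compound 4 (0.26 log units; within the scatter), also within the scatter. The unsubstituted phenyl of compound 4 therefore lies within the scatter of both compound 1 and compound 2, although those two differ beyond it.

Going by these compounds, whether an amine or a carboxylic acid at this position would move the number beyond the scatter remains open. No measurement shown here offers an explanation for these steps.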